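A few compounds are considered here, and "the series" means these few. Any claim that something is new, unique, unknown or untested is made for them only; others in the source may bear on it.

Series notes, a functional assay on MCF7 cells (Homo sapiens) for inhibition, read by MTT assay, with a stated time of 72 h; a higher number here means a weaker inhibitor, a lower number a stronger inhibitor:

- compound 1 `COc1cc2c(Oc3ccc(NC(=O)c4nn(-c5ccc(C)cc5C)cc(C)c4=O)cc3)ccnc2cc1OCCCCCCC(=O)NO`: 2430 nM
- compound 2 `COc1cc2c(Oc3ccc(NC(=O)c4nn(-c5ccccc5)cc(C)c4=O)cc3F)ccnc2cc1OCCCCCC(=O)NO`: 2330 nM
- compound 3 `COc1cc2c(Oc3ccc(NC(=O)c4nn(-c5ccccc5F)cc(C)c4=O)cc3F)ccnc2cc1OCCCC(=O)NO`: 2100 nM
- compound 4 `COc1cc2c(Oc3ccc(NC(=O)c4nn(-c5ccccc5C)cc(C)c4=O)cc3)ccnc2cc1OCCCCCCC(=O)NO`: not yet measured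

Compound 1 stands level with the other two measured compounds, as all three values lie within the scatter of one another. No order can be read among them.

Compound 4 is compound 1 with hydrogen in place of methyl on an aromatic carbon, the change from 2,4-dimethylphenyl to 2-methylphenyl. The site is meta to a methyl group and para to a large group. The counted difference is hydrogen in place of methyl on an aromatic carbon.

Among the compounds with values here, no measured pair differs in one place only, so the effect of this change has not been seen directly. The expectation rests on the narrow spread of values: compound 1 gives 2430 nM, compound 2 gives 2330 nM and compound 3 gives 2100 nM, although these compounds differ from one another in more than one place. In this assay, no step beyond the scatter is expected, in either direction. The estimated change is a 1.1-fold lower number from compound 1 to compound 4 (0.04 log units; within the scatter), which is expected to stay within the scatter. For compound 4 the expected value is 2200 nM, with an estimated range from 1100 nM to 4500 nM.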

Compound 4, half-maximal inhibitory concentration: 1830 nM
Estimate against measurement, compound 4: 1.2-fold (0.08 log units) above; low and high end bracket the measured number.
By their numbers in this assay, from the lowest: compounds 4, 3, 2 and 1 (each within the scatter of the next).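

In this assay the change from 2,4-dimethylphenyl to 2-methylphenyl gives the series its first step in one place only (a 1.3-fold lower number from compound 1 to compound 4 (0.12 log units; within the scatter)), and this step lies within the scatter. The earlier compounds shown here differ from one another in more than one place, so they could not isolate this site; the pair now shows that hydrogen in place of methyl on this aromatic carbon, para to a large group and meta to a methyl group, has no readable effect on the number in this assay. No measurement of any other kind is available to account for the size of this step.

As far as these compounds go, whether the site stays this flat for other groups remains open: a chlorine, a methoxy group or an amine in place of the methyl group would test this on the same 2-methylphenyl compound. The step also stands on a single chain length and without the fluorine carried by compound 2 and compound 3, so whether it holds with the other chain lengths or with that fluorine cannot be read from these compounds.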